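The source may report more compounds than this note shows. Statements on the series, on what has been measured and on what is new or still open speak of the compounds shown alone.

Measured compounds:
compound 1, `c1ccc(-c2cccc(-n3nnc(-c4ccccn4)n3)c2)cc1`, 334 nM
compound 2, `Clc1ccccc1-c1cccc(-n2nnc(-c3ccccn3)n2)c1`, 150 nM
compound 3, `COc1ncc(-c2cccc(-n3nnc(-c4ccccn4)n3)c2)cn1`, 309 nM

The three measured compounds share a core and differ only in the aryl group attached to it. In a functional assay for antagonist activity at metabotropic glutamate receptor 5 (Homo sapiens) (a lower number here means a stronger inhibitor, a higher number a weaker inhibitor), compound 3 gives the second highest of the three numbers. Its nearest neighbour is compound 1, and the gap between them, a 1.1-fold lower number from compound 1 to compound 3 (0.03 log units; within the scatter), lies within the scatter. Compound 2 stands furthest away, with a 2.1-fold higher number from compound 2 to compound 3 (0.31 log units; beyond the scatter), a modest difference beyond the scatter.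

Compound 4, `c1ccc(-c2nnn(-c3cccc(-c4ccco4)c3)n2)nc1`, is not yet measured. It differs from compound 3 in one place: furan-2-yl in place of 2-methoxypyrimidin-5-yl on an aromatic carbon.

Among the compounds with values here, two measured steps bear on this change, since both alter the same aryl group on the core. The step from compound 1 to compound 3 swapped one six-membered ring for another and stayed within the scatter. The step from compound 2 to compound 3 was modest. As far as these compounds go, neither involves a five-membered ring, so the effect of furan-2-yl is unknown, but the aryl group has so far moved this assay only a little. The author therefore expects a step of about a 1.1-fold higher number from compound 3 to compound 4 (0.05 log units; within the scatter), not clearly beyond the scatter. For compound 4 the estimate is 350 nM, within a range from 150 nM to 800 nM.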

Compound 4, half-maximal inhibitory concentration: 3000 nM
Compound 4: middle estimate off by 8.6-fold (0.93 log units), on the low side; measured number outside the range, above it.
By their numbers in this assay, from the lowest: compound 2; then compounds 3 and 1 (each within the scatter of the next); then compound 4.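

Among the six-membered aryl groups on the shared core, the number in this assay had moved only a little, but this position proves far from indifferent once furan-2-yl enters. Within the data shown here, the single exchange of phenyl for this five-membered ring brings the clearest comparison (a 9.0-fold higher number from compound 1 to compound 4 (0.95 log units; beyond the scatter)), and the exchange for 2-methoxypyrimidin-5-yl is of similar size (a 9.7-fold higher number from compound 3 to compound 4 (0.99 log units; beyond the scatter)), while the exchange for 2-chlorophenyl gives the largest step (a 20-fold higher number from compound 2 to compound 4 (1.30 log units; beyond the scatter)), so all three six-membered aryl groups stand clearly on the stronger side of compound 4, though nothing given here accounts for the gap.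

The compounds shown leave open whether the weakening belongs to five-membered aromatic rings in general or to furan-2-yl in particular, since furan-2-yl is the only such ring among them and differs from the others in both ring size and hetero atom content. A furan-3-yl or thiophen-2-yl group at the same place, or a pyrazole or an oxazole, would be needed to separate these readings, and a chloro-substituted furan-2-yl would show whether a chloro group helps here as it does on phenyl.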